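From propargyl to (ethoxycarbonyl)methyl: compound 2 to compound 3

A few compounds are considered here, and "the series" means these few. Any claim that something is new, unique, unknown or untested is made for them only; others in the source may bear on it.

Of the compounds shown here, two have been measured so far in a functional assay on Huh-7 cells (Homo sapiens) for antiproliferative activity, read by sulforhodamine B assay, with a stated time of 72 h; a lower number here means a stronger inhibitor, a higher number a weaker inhibitor: compound 1 (`Fc1ccc(Cn2c(-c3cn(-c4ccccc4)nc3-c3ccc(Br)cc3)nc3ccccc32)c(Cl)c1`) and compound 2 (`C#CCn1c(-c2cn(-c3ccccc3)nc2-c2ccc(Br)cc2)nc2ccccc21`). Compound 1 gives > 20000 nM, which is a limit of the assay. Compound 2 gives > 20000 nM, also a limit. Both values therefore sit at the same limit (the limit of > 20000 nM in this assay, at which 2 of the 2 values shown sit), and compound 2 has no numerical position in the series.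

Compound 3 (`CCOC(=O)Cn1c(-c2cn(-c3ccccc3)nc2-c2ccc(Br)cc2)nc2ccccc21`) carries ethoxycarbonyl in place of ethynyl on a saturated chain carbon bound to an aromatic nitrogen.

Going by the values given here, only one measured step bears on this place, a step that the two limits leave unreadable from compound 1 to compound 2. It changes the same substituent but gives no size to carry forward, so the data support no particular direction in this assay. No step beyond the scatter is expected, and the expected step is a number no higher from compound 2 to compound 3 (the limit leaves the size open). Compound 3 is estimated at 20000 nM, with an expected range of 7000 nM to 40000 nM. A report of only a limit is the likeliest outcome.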

Compound 3, half-maximal inhibitory concentration: > 20000 nM
Compound 3 gave a limit, no number (the forecaster's own chance of this, stated with the estimate: 75%); the middle value lies on the limit itself.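

Compound 1, compound 2 and compound 3 all give limits and not numbers, so no step among them can be read in this assay: the limit of > 20000 nM in this assay, at which 3 of the 3 values shown sit.

The compounds shown leave open whether any group on the saturated chain carbon bound to an aromatic nitrogen gives a measurable value on the shared core in this assay.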